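Isopropyl for Isobutyl on a Shared Core

The source may report more compounds than this note shows. Statements on the series, on what has been measured and on what is new or still open speak of the compounds shown alone.

Measured compounds:
compound 1 `COC(=O)[C@H](CC(C)C)NC(=O)c1ccc(/C=C2\SC(=O)N(CC(=O)NOCc3ccccc3)C2=O)cc1`: > 128000 nM
compound 2 `COC(=O)[C@H](CC(C)C)NC(=O)c1cccc(/C=C2\SC(=O)N(CC(=O)NOCc3ccccc3)C2=O)c1`: > 128000 nM

The assay is a functional assay on RAW264.7 cells (Mus musculus) for inhibition, read by microscopy and resazurin assay, with a stated time of 72 h; on this read-out higher numbers stand for weaker inhibition and lower numbers for stronger inhibition. In this assay compound 1 gives > 128000 nM, which is a limit of the assay and not a number. Compound 2 in this assay likewise gives > 128000 nM, again a limit. For the measured compounds named here, compound 1 therefore stands at the limit of > 128000 nM in this assay, at which 2 of the 2 values shown sit, with no numerical value of its own and no other compound that gives one.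

Compound 3 `COC(=O)[C@@H](NC(=O)c1ccc(/C=C2\SC(=O)N(CC(=O)NOCc3ccccc3)C2=O)cc1)C(C)C` has not yet been measured. It differs from compound 1 by isopropyl in place of isobutyl on a saturated chain carbon bound to an amide-type nitrogen and a carbonyl carbon. Going by the values given here, no step between two measured compounds is available to calibrate this change, so the expectation rests on the two limits alone. Compound 3 is expected to give about 200000 nM in this assay, within a range from 100000 nM to 500000 nM. This estimate amounts to an expected step that the limit leaves unreadable from compound 1 to compound 3, that is, nothing beyond the scatter, with the result most likely reported again as a limit.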

Compound 3, half-maximal inhibitory concentration: > 128000 nM
Compound 3: no number, only a limit; the forecaster's own chance of this, stated with the estimate: 85%; the middle value lies beyond the limit too.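

For the compounds shown here, compound 1 and compound 3 each give only a limit and not a number, so no step between them can be read. Whether any change on the shared core would give a numerical value in this assay remains open among the compounds shown.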